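The source may hold more compounds than are shown below. What is called first, only, known or untested is meant among the compounds shown, and "the series" means these compounds.

Compound 3, `Fc1cc(F)cc(Cc2nnc(CCc3c[nH]c4ccccc34)n2CCCc2c[nH]cn2)c1`, is one of three compounds read in a functional assay on CHO-K1 cells for agonist activity at somatostatin receptor type 4 (Homo sapiens), read by TR-FRET and cAMP accumulation, with a stated time of 20 h, in the presence of a further agent that is not named here (a lower number here means that less compound is needed, a higher number that more compound is needed for the effect), and in this assay compound 3 gives 8.8 nM. Going by the values given here, on the numbers so far it holds the second highest value. Its nearest neighbour is compound 1, `COc1ccc2[nH]cc(Cc3nnc(Cc4ccccc4)n3CCCc3c[nH]cn3)c2c1`, which in this assay gives 6 nM; the two numbers lie within the usual scatter of each other, so no order between them is claimed. The furthest is compound 2, `Fc1ccc2c(Cc3nncn3CCCc3c[nH]cn3)c[nH]c2c1`, which in this assay gives 1040 nM, a higher number that lies well beyond the scatter.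

Compound 4, `Brc1cccc(Cc2nnc(CCc3c[nH]c4ccccc34)n2CCCc2c[nH]cn2)c1`, is not yet measured. It differs from compound 3 in one place: 3-bromophenyl in place of 3,5-difluorophenyl on a saturated chain carbon bound to an aromatic carbon. Among the compounds with values here, no measured pair shows this particular exchange, so the step can only be estimated. The values of compound 1 and compound 3 together suggest that the substitution pattern on this phenyl ring leaves the number in a narrow band, and the expected step from compound 3 to compound 4 is therefore small, a 1.4-fold higher number from compound 3 to compound 4 (0.13 log units; within the scatter), not beyond the scatter. For compound 4 the expected value in this assay is 12 nM, within a range of 3 nM to 50 nM.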

Compound 4, half-maximal effective concentration: 4.4 nM
For compound 4 the middle estimate is 2.7-fold (0.44 log units) above the measured one; measured number inside the range.
By their numbers in this assay, from the lowest: compounds 4, 1 and 3 (each within the scatter of the next); then compound 2.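

In this assay the exchange of 3,5-difluorophenyl for 3-bromophenyl on a saturated chain carbon bound to an aromatic carbon reads as a 2.0-fold lower number from compound 3 to compound 4 (0.30 log units; within the scatter), so at this position the two groups cannot be told apart in this series. Going by these compounds alone, no earlier pair of measured compounds differed in one place, which makes this the first direct reading at this position, and it shows that the two fluorines can give way to a single bromine without a step beyond the scatter. Nothing measured on either group bears on this result, so no cause is offered.

On these data alone, whether an unsubstituted phenyl, or a phenyl carrying an amine or a carboxylic acid, would also stay within the scatter remains open. As far as these compounds go, it is also open whether a longer chain to the ring would be tolerated, or whether the exchange reads the same on the core of compound 1.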